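Bromo in Place of Chloro: Another Limit Expected

This account rests on a few compounds, and the source may have more. Where it says the series, first, only, none or still open, it means among the compounds named here.

Compound 2 `Clc1ccc(Cn2cc(COc3c(Cl)cc(Cl)cc3Cl)nn2)cc1` gives in an ADME assay on A549 cells (Homo sapiens) for inhibition, read by MTT assay, with a stated time of 48 h (on this read-out higher numbers stand for weaker inhibition of growth and lower numbers for stronger inhibition of growth), a value of > 100 ug/mL, which is a limit of the assay and not a number. Compound 1 `Cc1cc(OCc2cn(Cc3ccc(Cl)cc3)nn2)ccc1Cl` likewise reaches only > 100 ug/mL in this assay, again a limit. Both results sit at the limit of > 100 ug/mL in this assay, at which 2 of the 2 values shown sit. Compound 3 `Clc1cc(Cl)c(OCc2cn(Cc3ccc(Br)cc3)nn2)c(Cl)c1` differs from compound 2 by bromo in place of chloro on an aromatic carbon. Within the data shown here, no measured step covers this exchange, so the step from compound 2 to compound 3 a step that the limit leaves unreadable from compound 2 to compound 3 is expected to be none beyond the scatter. Compound 3 is therefore estimated at 150 ug/mL, between 60 ug/mL and 400 ug/mL, most likely again only a limit.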

Compound 3, concentration for 50% growth inhibition: > 100 ug/mL
Compound 3 gave a limit, no number (the forecaster's own chance of this, stated with the estimate: 80%); the middle value lies beyond the limit too.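

Compound 2 and compound 3 both give only a limit, so no step can be read for bromo in place of chloro: the limit of > 100 ug/mL in this assay, at which 3 of the 3 values shown sit.

The compounds shown leave open whether this exchange changes growth inhibition at all in this assay.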